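Replacing iodo with methoxy: working notes on compound 3

This account rests on a few compounds, and the source may have more. Where it says the series, first, only, none or still open, it means among the compounds named here.

For the measured compounds named here, in a functional assay on SK-OV-3 cells (Homo sapiens) for antiproliferative activity, read by MTT assay, with a stated time of 72 h (on this read-out lower numbers stand for stronger inhibition and higher numbers for weaker inhibition), compound 2 `O=C(CCc1cccc2c1B(O)OC2)Nc1ccc(I)cc1` gives 51000 nM as the only actual number so far. Compound 1 `CCNC(=O)CCc1cccc2c1B(O)OC2` gives > 100000 nM in the same read-out, and that value is a limit of the assay and not a number.

Compound 3 `COc1ccc(NC(=O)CCc2cccc3c2B(O)OC3)cc1` has methoxy in place of iodo on an aromatic carbon, para to a large group, and otherwise matches compound 2 (methoxy in place of iodo on an aromatic carbon).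

Going by the values given here, the sole measured step is an at least 1.9-fold lower number from compound 1 to compound 2 (0.29 log units; that floor lies within the scatter) and it concerns the group on the amide-type nitrogen, where 4-iodophenyl replaces ethyl. It does not compare groups on the aromatic carbon that changes here, so it gives no direct measure of this swap. With compound 2 at 51000 nM as the anchor, no step beyond the scatter is expected in this assay and the data settle no direction. The expected change is a 1.2-fold higher number from compound 2 to compound 3 (0.07 log units; within the scatter) on this estimate. Compound 3 may also be expected to return only a limit of the assay.

For compound 3 the estimated value is 60000 nM with an expected range from 25000 nM to 100000 nM in this read-out.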

Compound 3, half-maximal inhibitory concentration: 900 nM
For compound 3 the middle estimate is 67-fold (1.82 log units) above the measured one; measured number outside the range, below it.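

For the compounds shown here, the aromatic carbon para to a large group proves far more responsive in this assay than the earlier compounds could indicate, with methoxy in place of iodo giving a 57-fold lower number from compound 2 to compound 3 (1.75 log units; beyond the scatter). Going by these compounds alone, the only earlier step, an at least 1.9-fold lower number from compound 1 to compound 2 (0.29 log units; that floor lies within the scatter), concerned the group on the amide-type nitrogen, had a floor within the scatter, and said nothing about this carbon. The swap itself is small by count, with iodo leaving as 1 heavy atom and methoxy entering as 2 heavy atoms and 1 hydrogen-bond acceptor, with no ring or net charge involved, yet the step lies well beyond the scatter.

Within the data shown here, with only two groups compared on this carbon, the data cannot separate the departure of iodo from the arrival of methoxy, and a hydroxy, ethoxy or amino group there would show whether the oxygen or the methyl part of methoxy carries the step. Compound 1 remains a limit of the assay and not a number, so the ethyl group on the nitrogen still has no sized comparison within the series: the limit of > 100000 nM in this assay, at which 1 of the 3 values shown sits.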